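Methoxy Added to a Methylated Core: Expected Inhibition

The source may hold more compounds than are shown below. What is called first, only, known or untested is meant among the compounds shown, and "the series" means these compounds.

Measured so far:
- compound 1, `COc1ccc(-c2cc3[nH]nc(N)c3c(=O)[nH]2)cc1`: 62%
- compound 2, `Cn1nc(N)c2c(=O)[nH]c(-c3ccccc3)cc21`: 9%

In an assay on isolated protein for inhibition of ribosomal protein S6 kinase alpha-5 (Homo sapiens), read by mobility shift assay, tested at 30 uM (on this read-out higher numbers stand for more inhibition at the one concentration tested (going by the name of the read-out) and lower numbers for less inhibition), compound 2 gives 9%, the lowest of the two numbers; compound 1 stands higher by a margin that is beyond the usual scatter, but the two compounds differ in more than one place, so no single change can be credited. Compound 3, `COc1ccc(-c2cc3c(c(N)nn3C)c(=O)[nH]2)cc1`, differs from compound 2 by methoxy in place of hydrogen on an aromatic carbon. As far as these compounds go, its effect on the methylated core is unknown from these data. A small upward step is expected, a number 11 percentage points higher from compound 2 to compound 3 (beyond the scatter), since compound 1 carries the methoxy and gives 62%. Compound 3 is estimated at 20%, within 5% to 45%.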

Compound 3, a percentage reported as inhibition, at one concentration (the size of the read-out at that concentration, not a potency): 9%
Beside the measured number, compound 3's estimate is 11 percentage points above it; measured number inside the range.
By their numbers in this assay, from the lowest: compounds 2 and 3 (each within the scatter of the next); then compound 1.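

In this assay, methoxy in place of hydrogen on an aromatic carbon, para to a large group, gives no change at the digits printed from compound 2 to compound 3 (within the scatter) and so does not restore inhibition on the methylated core. With the methoxy kept, methyl in place of hydrogen on an aromatic nitrogen gives a number 53 percentage points lower from compound 1 to compound 3 (beyond the scatter) and so ties the loss to that single change. Nothing measured here explains this loss.

Still open, as far as these compounds go, is whether a longer chain such as ethyl on that nitrogen would also lose inhibition. Also open, from the compounds shown here alone, is how an amine in place of the methoxy would read on either core.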